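Cytotoxicity notes on a halophenyl pair

A few compounds are considered here, and "the series" means these few. Any claim that something is new, unique, unknown or untested is made for them only; others in the source may bear on it.

The set rests on one shared core carrying a substituted phenyl ring: compound 1 is `C[C@]1(CN2CCc3nc(-c4ccc(Cl)cc4)ccc3C2)Cn2cc([N+](=O)[O-])nc2O1`, compound 2 is `C[C@]1(CN2CCc3nc(-c4cc(F)cc(F)c4)ccc3C2)Cn2cc([N+](=O)[O-])nc2O1` and compound 3 is `C[C@]1(CN2CCc3nc(-c4ccc(F)c(Cl)c4)ccc3C2)Cn2cc([N+](=O)[O-])nc2O1`. In an ADME assay on Vero cells (Chlorocebus sabaeus) for cytotoxicity, read by MTT assay, with a stated time of 72 h (on this read-out lower numbers stand for higher toxicity in this test and higher numbers for lower toxicity in this test), compound 1 gives "not determined" (no result reported). In this assay compound 2 gives > 32 ug/mL, which is a limit of the assay and not a number. Compound 2 therefore stands at the limit described by the limit of > 32 ug/mL in this assay, at which 1 of the 2 values shown sits, while the only other measured entry carries no number at all. Within the data shown here, no step between two measured compounds exists here, so nothing sets a size against which the next change can be read.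

The change from compound 2 to compound 3 is 3-chloro-4-fluorophenyl in place of 3,5-difluorophenyl on an aromatic carbon. One halogen is swapped for another on the same ring, and no donor or acceptor count moves. The expected step is a step that the limit leaves unreadable from compound 2 to compound 3, no more than the usual scatter, with a limit once more the most probable outcome. For compound 3 the estimate is 40 ug/mL, within a range from 20 ug/mL to 100 ug/mL.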

Compound 3, half-maximal cytotoxic concentration: > 32 ug/mL
Compound 3: a limit, no number (the forecaster's own chance of this, stated with the estimate: 75%); the middle value lies beyond the limit too.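

The step from compound 2 to compound 3 cannot be read, because both entries are limits of the assay and not numbers: the limit of > 32 ug/mL in this assay, at which 2 of the 3 values shown sit.

The compounds shown leave open where the half-maximal cytotoxic concentration of compound 2 and compound 3 lies in this assay, and whether exchanging 3,5-difluorophenyl for 3-chloro-4-fluorophenyl changes that read-out at all.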